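The source may hold more compounds than are shown below. What is called first, only, known or untested is meant among the compounds shown, and "the series" means these compounds.

Compound 1 `CC(=O)N1CCc2nc(C)c(C(OC(C)(C)C)C(=O)O)c(-c3ccc(C)cc3)c2C1` carries an acetyl on the ring amine nitrogen of the shared core. In an ADME assay on MT2 cells (Homo sapiens) for cytotoxicity, read by XTT assay, with a stated time of 4 days (on this read-out lower numbers stand for higher toxicity in this test and higher numbers for lower toxicity in this test), compound 1 gives > 40000 nM, a limit of the test rather than a number. Compound 2 `Cc1ccc(-c2c3c(nc(C)c2[C@H](OC(C)(C)C)C(=O)O)CCN(CCCc2ccccc2)C3)cc1` likewise reaches only a limit: in this assay compound 2 gives > 40000 nM. What is known is therefore (the limit of > 40000 nM in this assay, at which 2 of the 2 values shown sit). Compound 3 `Cc1ccc(-c2c3c(nc(C)c2C(OC(C)(C)C)C(=O)O)CCN(CCCC2CCCC2)C3)cc1` differs from compound 1 by 3-cyclopentylpropyl in place of acetyl on an amine nitrogen in a ring. Among the measured compounds shown here, no measured step links them, and the expected step of a number no higher from compound 1 to compound 3 (the limit leaves the size open) is none beyond the scatter. Compound 3 is thus expected to give about 40000 nM, between 15000 nM and 80000 nM.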

Compound 3, half-maximal cytotoxic concentration: > 40000 nM
Compound 3: a limit, no number; the forecaster's own chance of this, stated with the estimate: 70%; the middle value sits exactly at the limit.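

Between compound 1 and compound 3 no step can be read, since both values are limits of the test and not numbers. Where the half-maximal cytotoxic concentration of any compound shown actually lies stays open: the limit of > 40000 nM in this assay, at which 3 of the 3 values shown sit.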